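From hexyl to cyclobutyl: a stability estimate for compound 4

The source may report more compounds than this note shows. Statements on the series, on what has been measured and on what is new or still open speak of the compounds shown alone.

Compound 1 `CCCCCCNC(=O)Oc1cccc(-c2ccccc2)c1` gives 46.7%
Compound 2 `NC(=O)c1cccc(-c2cccc(OC(=O)NCCCCc3ccccc3)c2)c1` gives 18.8%
Compound 3 `O=C(NC1CCCC1)Oc1cccc(-c2ccccc2)c1` gives 34.4%

These three numbers all come from a physicochemical assay, read by HPLC, in phosphate buffer, at pH 7.0 (on this read-out lower numbers stand for a less stable compound and higher numbers for a more stable compound), and compound 1 stands highest among them, with both other compounds lower by more than the usual scatter. The next compound to be tested is compound 4 `O=C(NC1CCC1)Oc1cccc(-c2ccccc2)c1` which keeps the core of compound 1 and carries cyclobutyl in place of hexyl on an amide-type nitrogen. Counted out, the swap reads cyclobutyl in place of hexyl on an amide-type nitrogen and nothing else changes.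

Within the data shown here, one measured step bears directly on this swap. It is a number 12.3 percentage points lower from compound 1 to compound 3 (beyond the scatter) and it also puts a carbon ring where the hexyl stood, with cyclopentyl at the same place. Compound 2 differs from compound 1 in more than one place, so it offers no clean comparison. With compound 3 at 34.4% as the closest guide, a fall of similar modest size is expected in this assay for the slightly smaller ring. The estimated change is a number 14.7 percentage points lower from compound 1 to compound 4 (beyond the scatter) and would lie beyond the scatter, though one step is thin evidence. For compound 4 the expected value is 32% with an estimated range from 18% to 46% until a measurement is available.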

Compound 4, percent of the compound remaining: 22.6%
Compound 4: the middle estimate sits 9.4 percentage points above what was measured; low and high end bracket the measured number.
By their numbers in this assay, from the lowest: compounds 2 and 4 (each within the scatter of the next); then compound 3; then compound 1.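

Replacing hexyl with cyclobutyl on the amide-type nitrogen gives a number 24.1 percentage points lower from compound 1 to compound 4 (beyond the scatter) in this assay and adds a second ring to the comparison, so this position can now be judged on more than one ring. The direct comparison of the two rings gives a number 11.8 percentage points lower from compound 3 to compound 4 (beyond the scatter) and shows that cyclopentyl and cyclobutyl are not interchangeable here, since a change confined to the ring on this nitrogen is enough to move the number by more than the usual scatter. Among compound 1, compound 3 and compound 4, the open hexyl chain stands highest and the four-membered ring lowest, but nothing measured here explains that order.

The compounds shown leave open whether the lower numbers follow from having a ring at all or from having fewer carbons on the nitrogen, a question that a plain butyl chain, with no ring, could help separate. They also leave open how a larger ring such as cyclohexyl, or a chain longer than hexyl such as octyl, would behave at this same position on the shared core.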